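The source may report more compounds than this note shows. Statements on the series, on what has been measured and on what is new or still open speak of the compounds shown alone.

Working notes on the series in a functional assay on HCT-116 cells (Homo sapiens) for cytotoxicity; a higher number here means that more compound is needed for the effect, a lower number that less compound is needed. The compounds share one core and differ in a single aryl substituent. Compound 1 `CC(=O)SCC(=O)c1ccc(NS(=O)(=O)c2cccc(Cl)c2)cc1` stands at "not determined" (no result reported). Within the data shown here, compound 2 `CC(=O)SCC(=O)c1ccc(NS(=O)(=O)c2ccc(Cl)cc2)cc1` gives 30800 nM, the only numerical result so far. Compound 3 `CC(=O)SCC(=O)c1ccc(NS(=O)(=O)c2ccc(F)cc2)cc1` stands at "not determined" (no result reported), so it has no single number in this assay and offers no direct reference point. Compound 1 is the one other entry without a number.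

Compound 4 `COc1ccc(S(=O)(=O)Nc2ccc(C(=O)CSC(C)=O)cc2)cc1` follows from compound 3 by one change, methoxy in place of fluoro on an aromatic carbon, para to a large group, so that 4-fluorophenyl becomes 4-methoxyphenyl.

Among the measured compounds shown here, no step between measured compounds is available, so the data give no direct measure of what a change at this place does in this assay. The expectation is therefore a step no larger than the scatter, with no direction favoured, and it rests only on compound 2 at 30800 nM as the nearest measured neighbour. With a single anchor, the range is kept wide. For compound 4 the estimated half-maximal effective concentration is 30000 nM, with an expected range of 10000 nM to 80000 nM.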

Compound 4, half-maximal effective concentration: 500 nM
The estimate for compound 4 lay 60-fold (1.78 log units) above the measured number; the measured number lies below the stated range.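

The aromatic carbon para to a large group is now shown to matter in this assay: methoxy in place of chloro there gives a 62-fold lower number from compound 2 to compound 4 (1.79 log units; beyond the scatter), the first measured step in the series, and the only one that shows how far a change at this place can move the number. The change of 4-fluorophenyl to 4-methoxyphenyl itself cannot be read, as compound 3 has no single number, so the size of the effect rests on the chloro and methoxy pair alone. Nothing on hand accounts for a step of this size, and the reading stays purely empirical.

Whether the low number is particular to methoxy or extends to other groups at this place stays open: the compounds shown include no ethoxy, hydroxy or amine there, and so the width of the effect across related substituents cannot be judged. As far as these compounds go, it is equally open whether the step carries over to other parts of the molecule, as the shared core stays unchanged throughout and no variant with a carboxylic acid or a longer chain on it appears.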